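The compounds below may be only part of what the source reports. "The series", "measured", "known", "first", "only" and "open" are said of these compounds alone.

Working notes on one shared core carrying a five-membered ring, measured in a functional assay on the whole organism for inhibition, with Rattus norvegicus as the target, read by paw edema; a higher number here means that more compound is needed for the effect, a lower number that less compound is needed. Compound 1 `O=C(O)c1cc(-c2c[nH]cn2)ccc1O` gives 100 mg/kg in this assay. Compound 3 `O=C(O)c1cc(-c2ncco2)ccc1O` gives 100 mg/kg, and the step of no change at the digits printed from compound 1 to compound 3 (within the scatter) leaves the two level at the digits shown, so compound 1 stands with compound 3 and no order between them can be read. Compound 2 `O=C(O)c1cc(-c2cc[nH]n2)ccc1O` is reported only as a limit of the assay, > 250 mg/kg, as recorded in the limit of > 250 mg/kg in this assay, at which 1 of the 3 values shown sits. The step of an at least 2.5-fold higher number from compound 1 to compound 2 (0.39 log units; beyond the scatter) is thus at least modest, and an at least 2.5-fold lower number from compound 2 to compound 3 (0.39 log units; beyond the scatter) runs the opposite way by the same margin.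

Compound 4 `O=C(O)c1cc(-n2ccnn2)ccc1O` is not yet measured. Its change from compound 1: 1H-1,2,3-triazol-1-yl in place of 1H-imidazol-4-yl on an aromatic carbon. Among the compounds with values here, two measured steps bear on this exchange of one five-membered ring for another on the same aromatic carbon. The move to 1,3-oxazol-2-yl left the number unchanged in no change at the digits printed from compound 1 to compound 3 (within the scatter); the move to 1H-pyrazol-3-yl gave an at least modest rise in an at least 2.5-fold higher number from compound 1 to compound 2 (0.39 log units; beyond the scatter). On that evidence the expected step of a 1.3-fold higher number from compound 1 to compound 4 (0.11 log units; within the scatter) is small, leaning if anything toward a higher number, and most likely within the scatter. Compound 4 is therefore estimated at 130 mg/kg in this assay, within a range of 60 mg/kg to 300 mg/kg.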

Compound 4, dose for half-maximal effect: 150 mg/kg
The estimate for compound 4 lay 1.2-fold (0.06 log units) below the measured number; low and high end bracket the measured number.
By their numbers in this assay, from the lowest: compounds 1, 3 and 4 (each within the scatter of the next). At a limit, above all of these: compound 2.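

The step of a 1.5-fold higher number from compound 1 to compound 4 (0.18 log units; within the scatter) in this assay shows that this place tolerates the exchange of 1H-imidazol-4-yl, with its hydrogen-bond donor, for 1H-1,2,3-triazol-1-yl, which has none, so that donor is not required for compounds 1 and 4 to stand level. The step of a 1.5-fold higher number from compound 3 to compound 4 (0.18 log units; within the scatter) puts the 1H-1,2,3-triazol-1-yl group level with 1,3-oxazol-2-yl as well, so the three rings of compounds 1, 3 and 4, meta to the carboxy group and para to the hydroxy group, cannot be told apart in this assay, while compound 2 is the one that goes against this grouping. Compound 2 is recorded only as a limit of the assay, and the step of an at least 1.6-fold lower number from compound 2 to compound 4 (0.22 log units; that floor lies within the scatter) has a floor that does not by itself separate the two compounds, unlike the steps to it from compounds 1 and 3: the limit of > 250 mg/kg in this assay, at which 1 of the 4 values shown sits.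

What the compounds shown leave open is whether a six-membered ring, an amine or a longer alkyl chain at this place would hold the same level. They also do not show what sets the 1H-pyrazol-3-yl group of compound 2 apart, or how far its true number lies from the other three.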